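This account rests on a few compounds, and the source may have more. Where it says the series, first, only, none or still open, it means among the compounds named here.

Measured compounds:
- Compound 1 `N#C/C(=C\c1ccoc1)C(=O)NC1CCCCC1`: 0%
- Compound 2 `CC(C)(C)OC(=O)/C(C#N)=C/c1cc2ccccc2[nH]1`: 51.3%

The two measured compounds were tested in a functional assay on the whole organism (strain CD1) for inhibition, with Mus musculus as the target, with stated times of 15 min and 20 min, at a dose of 10 mg/kg by the subcutaneous route; a higher number here means more inhibition at the dose given (going by the name of the read-out), a lower number less inhibition. Compound 1 gives 0% there, while compound 2 gives 51.3%, so compound 2 stands highest of the two numbers, and the gap to compound 1 lies beyond the usual scatter. The two compounds differ in more than one place, so nothing can be said about which part of the difference carries that gap.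

Compound 3 `N#C/C(=C\c1cc2ccccc2[nH]1)C(=O)Nc1ccccc1` has not yet been measured. It differs from compound 2 by anilino in place of tert-butoxy on a carbonyl carbon. Compound 3 keeps the core of compound 2, the part that compound 1 lacks, but it carries an amide like compound 1 rather than an ester. Because compound 1 gives 0% with an amide and compound 2 gives 51.3% with an ester, the expected step is a modest drop, a number 11.3 percentage points lower from compound 2 to compound 3 (beyond the scatter), though with wide uncertainty. Compound 3 is therefore estimated to give about 40% in this assay, expected to fall within 5% to 75%.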

Compound 3, a percentage reported as inhibition, in the whole organism at one dose (the size of the read-out at that dose, not a potency): 52%
The estimate for compound 3 lay 12 percentage points below the measured number; low and high end bracket the measured number.
By their numbers in this assay, from the lowest: compound 1; then compounds 2 and 3 (each within the scatter of the next).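

In this assay, anilino in place of tert-butoxy on a carbonyl carbon gives a number 0.7 percentage points higher from compound 2 to compound 3 (within the scatter). For the compounds shown here, this is the first comparison in which only this position changes, and it shows that on the shared core the read-out does not depend on keeping the ester: the amide of compound 3 serves as well as the ester of compound 2 at this dose, even though a six-membered aromatic ring and a hydrogen-bond donor enter and the tert-butoxy group leaves. No accompanying measurement bears on this step, so the data offer no account of why the two numbers stay within the scatter of each other.

The compounds shown leave open how far this freedom extends, since a single exchange cannot tell whether a carboxylic acid, a methoxy group or benzylamino on the same carbonyl carbon would hold the read-out as well. They also leave open whether compound 2 and compound 3 would still match at other doses, as a percentage at one dose is not a potency.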